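Changing the group on the sulfonyl sulfur

A few compounds are considered here, and "the series" means these few. Any claim that something is new, unique, unknown or untested is made for them only; others in the source may bear on it.

Compound 1 `CC(=O)N1CCC(S(=O)(=O)c2ccc(CNC(=O)N3Cc4ccncc4C3)cc2)CC1`: 110 nM
Compound 2 `O=C(NCc1ccc(S(=O)(=O)N2CCC[C@H](O)C2)cc1)N1Cc2ccncc2C1`: 150 nM

In a functional assay on A2780 cells (Homo sapiens) for cytotoxicity, read by sulforhodamine B assay, with a stated time of 72 h (on this read-out lower numbers stand for stronger inhibition and higher numbers for weaker inhibition), compound 2 gives 150 nM. This lies within the usual scatter of compound 1, so the two numbers cannot be ranked.

The next compound, compound 3 `O=C(NCc1ccc(S(=O)(=O)N2CCC(N3CCCC3)CC2)cc1)N1Cc2ccncc2C1`, changes the same place again: 4-(pyrrolidin-1-yl)piperidin-1-yl in place of 3-hydroxypiperidin-1-yl on a sulfonyl sulfur. Put simply, 4-(pyrrolidin-1-yl)piperidin-1-yl comes in place of 3-hydroxypiperidin-1-yl on the sulfonyl sulfur.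

For the measured compounds named here, only one measured step bears on this place: a 1.4-fold higher number from compound 1 to compound 2 (0.13 log units; within the scatter). That exchange stayed within the scatter, which gives a first hint that the number may tolerate different groups here. It is thin evidence, however. The entering group brings a five-membered non-aromatic ring that neither measured compound carries at this place.

From the compounds shown here alone, no step beyond the scatter is therefore expected in this assay, and the direction remains open. The expected step is a 1.2-fold lower number from compound 2 to compound 3 (0.06 log units; within the scatter). For compound 3 the estimated value is 130 nM, with an expected range from 40 nM to 420 nM.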

Compound 3, half-maximal inhibitory concentration: 5.6 nM
Beside the measured number, compound 3's estimate is 23-fold (1.37 log units) above it, and the stated range ends above it.
By their numbers in this assay, from the lowest: compound 3; then compounds 1 and 2 (each within the scatter of the next).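

In this assay the group on the sulfonyl sulfur clearly matters: putting 4-(pyrrolidin-1-yl)piperidin-1-yl in place of 3-hydroxypiperidin-1-yl gives a 27-fold lower number from compound 2 to compound 3 (1.43 log units; beyond the scatter) and putting it in place of 1-acetylpiperidin-4-yl gives a 20-fold lower number from compound 1 to compound 3 (1.29 log units; beyond the scatter) with both steps beyond the scatter. For the compounds shown here, the only earlier step at this place, a 1.4-fold higher number from compound 1 to compound 2 (0.13 log units; within the scatter) stayed within the scatter, so compounds 1 and 2 gave no sign of how far the number could move with a change here. No measurement shown explains why the entering group gives such a low number.

The compounds shown cannot tell whether the step depends on the five-membered pyrrolidine ring or would also appear with another group at the 4-position of the piperidine. A 4-(dimethylamino)piperidin-1-yl or a 4-(morpholin-4-yl)piperidin-1-yl group on the sulfonyl sulfur would help separate these possibilities, since each keeps the piperidine and replaces only the pyrrolidine ring.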